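Swapping cyclopropyl for cyclobutyl on a formamide nitrogen

The source may report more compounds than this note shows. Statements on the series, on what has been measured and on what is new or still open speak of the compounds shown alone.

Compound 1 `O=CN(C1CCCC1)C1CC1` is a small formamide carrying two saturated rings on its nitrogen. In an assay on isolated protein for inhibition of alcohol dehydrogenase 1A (Homo sapiens) (a higher number here means a weaker inhibitor, a lower number a stronger inhibitor), compound 1 gives 880 nM, the lowest of the two numbers recorded so far. The other measured member of the set, compound 2 `O=CN(C1CCC1)C1CCC1`, carries two identical four-membered rings; in this assay compound 2 gives 1800 nM, which stands beyond the scatter above the number for compound 1.

The new compound, compound 3 `O=CN(C1CCCC1)C1CCC1`, keeps the five-membered ring of compound 1 and changes only the other ring: cyclobutyl in place of cyclopropyl on an amide-type nitrogen. Among the compounds with values here, no step between measured compounds isolates this exact change, so the expectation rests on the two numbers at hand. Because compound 2 gives 1800 nM with two cyclobutyl groups, a modest move toward a higher number is expected for compound 3, most likely within or just at the edge of the usual scatter, as a 1.4-fold higher number from compound 1 to compound 3 (0.13 log units; within the scatter). Compound 3 is therefore estimated at 1200 nM in this assay, with a plausible range from 500 nM to 2800 nM.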

Compound 3, inhibition constant: 360 nM
For compound 3 the middle estimate is 3.3-fold (0.52 log units) above the measured one; the measured number lies below the stated range.
By their numbers in this assay, from the lowest: compound 3; then compound 1; then compound 2.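

In this assay, cyclobutyl in place of cyclopropyl on an amide-type nitrogen gives a 2.4-fold lower number from compound 1 to compound 3 (0.39 log units; beyond the scatter), so this position does respond to the ring placed there, and the ring with one more carbon goes with the stronger inhibitor in this pair. Compound 2 also carries cyclobutyl, yet compound 2 gives 1800 nM, so the earlier numbers could easily be read as a warning against this ring; compound 3 shows that cyclobutyl is well tolerated when the five-membered ring of compound 1 stays in place, and the effect of the swap therefore has to be judged with the other ring on the nitrogen in view. Nothing available gives a measured reason for this gain in binding.

From the compounds shown here alone, two ring sizes at one position make only a short series, so it remains open whether the number keeps falling with a still larger ring at this place, such as cyclohexyl, or turns back up. Open-chain groups such as isopropyl or tert-butyl, and a flat aromatic ring such as phenyl, would show whether a saturated ring is needed here at all.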